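A few compounds are considered here, and "the series" means these few. Any claim that something is new, unique, unknown or untested is made for them only; others in the source may bear on it.

The measured compounds, with their values in an assay for inhibition of Nicotinamide phosphoribosyltransferase (Homo sapiens), read by mass spectrometry, with stated times of 15 min and 30 min; a higher number here means a weaker inhibitor, a lower number a stronger inhibitor:
compound 1, `Cc1ccccc1S(=O)(=O)c1ccc(CNC(=O)c2cc3cnccc3[nH]2)cc1`, gives 12 nM
compound 2, `O=C(NCc1ccc(S(=O)(=O)c2cccc(F)c2)cc1)c1cc2cnccc2[nH]1`, gives 5 nM
compound 3, `O=C(NCc1ccc(S(=O)(=O)c2ccccc2C(F)(F)F)cc1)c1cc2cnccc2[nH]1`, gives 24 nM

Compound 3 has the highest of the three numbers in this assay. Its nearest neighbour is compound 1, with a 2.0-fold higher number from compound 1 to compound 3 (0.30 log units; within the scatter), a step that stays within the scatter; its furthest is compound 2, with a 4.8-fold higher number from compound 2 to compound 3 (0.68 log units; beyond the scatter). Compound 4, `O=C(NCc1ccc(S(=O)(=O)c2cccc(C(F)(F)F)c2)cc1)c1cc2cnccc2[nH]1`, differs from compound 3 by the change (3-(trifluoromethyl)phenyl in place of 2-(trifluoromethyl)phenyl on a sulfonyl sulfur). Going by the values given here, no measured pair shows exactly this move of a trifluoromethyl from one place on the phenyl to another. The closest guides are a 2.4-fold lower number from compound 1 to compound 2 (0.38 log units; beyond the scatter), where the group on the phenyl changed both its place and its identity, and a 4.8-fold higher number from compound 2 to compound 3 (0.68 log units; beyond the scatter), where the 3-fluorophenyl compound held the lowest number of the set. Together these hint that a group placed as in 3-fluorophenyl and 3-(trifluoromethyl)phenyl may give a lower number than one placed as in 2-methylphenyl and 2-(trifluoromethyl)phenyl, though the comparison is indirect and rests on only three compounds. Compound 4 is therefore expected to show a modestly lower number than compound 3, a 2.4-fold lower number from compound 3 to compound 4 (0.38 log units; beyond the scatter), with considerable uncertainty. The estimate for compound 4 in this assay is 10 nM, within a range from 4 nM to 25 nM.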

Compound 4, half-maximal inhibitory concentration: 8 nM
Beside the measured number, compound 4's estimate is 1.3-fold (0.10 log units) above it; measured number inside the range.
By their numbers in this assay, from the lowest: compounds 2, 4, 1 and 3 (each within the scatter of the next, the first and the last beyond it).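

In this assay, going by these compounds alone, moving the trifluoromethyl to give 3-(trifluoromethyl)phenyl in place of 2-(trifluoromethyl)phenyl on the sulfonyl sulfur produces a 3.0-fold lower number from compound 3 to compound 4 (0.48 log units; beyond the scatter), and this is the first pair in which the group keeps its identity and only its place changes, so place alone can move the number. Identity counts for less among the 3-substituted phenyls, since trifluoromethyl in place of fluoro on the aromatic carbon gives a 1.6-fold higher number from compound 2 to compound 4 (0.20 log units; within the scatter), but the advantage of the 3-substituted phenyl is not general: 3-(trifluoromethyl)phenyl in place of 2-methylphenyl gives a 1.5-fold lower number from compound 1 to compound 4 (0.18 log units; within the scatter), so compound 1 goes against any simple rule based on place. Nothing available here explains the difference between these two placements of the trifluoromethyl.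

The compounds shown leave open whether place would matter as much for another group on this phenyl, such as a methoxy group or a chlorine atom. They also leave open how an amine or a carboxylic acid on the same ring would behave in this assay.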